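A few compounds are considered here, and "the series" means these few. Any claim that something is new, unique, unknown or untested is made for them only; others in the source may bear on it.

Of the compounds shown here, two built on one shared core have been measured in a functional assay on a cell-free system (Platelet, plasma, Homo sapiens), with stated times of 4 min and 5.5 min, tested at 1 uM; on this read-out lower numbers stand for a stronger effect and higher numbers for a weaker effect at the one concentration tested. Compound 1 `O=C(C1CCCN(Cc2ccccc2F)C1)N1CCN(c2ccccc2Cl)CC1` gives 50%. Compound 2 `O=C(C1CCCN(Cc2ccc(F)cc2)C1)N1CCN(c2ccccc2Cl)CC1` gives 40%. Among the compounds with values here, the one step between them, a number 10 percentage points lower from compound 1 to compound 2 (within the scatter), goes with 4-fluorophenyl in place of 2-fluorophenyl on a saturated chain carbon bound to an amine nitrogen in a ring. Within the data shown here, of the two numbers, the one for compound 2 is the smaller, though its gap to compound 1 lies within the scatter and so marks no real difference.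

Compound 3 `O=C(C1CCCN(Cc2ccc([N+](=O)[O-])cc2)C1)N1CCN(c2ccccc2Cl)CC1` has not yet been measured. It differs from compound 2 by nitro in place of fluoro on an aromatic carbon. Among the measured compounds shown here, no measured step swaps a fluoro for a nitro, so none bears directly on this change; the single step seen shows only that moving the fluoro around the ring leaves the read-out within the scatter. A step of a number 5 percentage points higher from compound 2 to compound 3 (within the scatter) in this assay is therefore expected, no larger than the scatter and with no direction to favour. Compound 3 is estimated at 45%, within a range from 20% to 75%.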

Compound 3, a percentage reported as activity, at one concentration (the size of the read-out at that concentration, not a potency): 23%
Beside the measured number, compound 3's estimate is 22 percentage points above it; low and high end bracket the measured number.
By their numbers in this assay, from the lowest: compound 3; then compounds 2 and 1 (each within the scatter of the next).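

In this assay, within the data shown here, the group at this place on the ring proves able to shift the read-out: nitro in place of fluoro gives a number 17 percentage points lower from compound 2 to compound 3 (beyond the scatter) and is the first change of a group here to go beyond the scatter, whereas the earlier step, which only moved the fluoro around the ring, stayed within it. The wider change to 4-nitrophenyl from 2-fluorophenyl gives a number 27 percentage points lower from compound 1 to compound 3 (beyond the scatter) and also goes beyond the scatter, so compound 3 shows the strongest effect of the three at the one concentration tested. Nothing available explains why nitro and fluoro differ here, and the numbers alone record only that they do.

Still open, as far as these compounds go, is whether other groups on this aromatic carbon, such as a nitrile, a methoxy, an amine or a carboxylic acid, would match compound 3 or fall back towards compound 2. Also open, from the compounds shown here alone, is whether nitro would give a similar step in the place the fluoro holds in compound 1, and whether the gap would persist across a range of concentrations.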